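N-acylation of the core: para to meta chloride move

A few compounds are considered here, and "the series" means these few. Any claim that something is new, unique, unknown or untested is made for them only; others in the source may bear on it.

Measured compounds in a functional assay on PC-3 cells (Homo sapiens) for cytotoxicity, read by sulforhodamine B assay, with a stated time of 72 h; a higher number here means a weaker inhibitor of growth, a lower number a stronger inhibitor of growth:
compound 1 `O=C(Nc1cc(C(F)(F)F)cc(C(F)(F)F)c1)C1CCc2ccccc2N1C(=O)c1ccc(Cl)cc1`: 4230 nM
compound 2 `O=C(Nc1cc(C(F)(F)F)cc(C(F)(F)F)c1)C1CCc2ccccc2N1`: 8120 nM

Compound 2 gives the highest of the two numbers in this assay, with compound 1 as its nearest neighbour; the two values lie within the scatter of each other, so no order between them can be claimed.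

Compound 3 `O=C(Nc1cc(C(F)(F)F)cc(C(F)(F)F)c1)C1CCc2ccccc2N1C(=O)c1cccc(Cl)c1` is the next compound of the series and has not yet been measured. It differs from compound 2 by (3-chlorophenyl)carbonyl in place of hydrogen on a nitrogen on an aromatic ring in a ring.

Among the compounds with values here, the one measured step that bears on this change is a 1.9-fold higher number from compound 1 to compound 2 (0.28 log units; within the scatter), which removed an acyl group of the same kind from the same nitrogen and stayed within the scatter. Compound 3 restores such an acyl group, with the chlorine at the 3-position of the phenyl rather than the 4-position. On these numbers the step is expected to be small, toward a lower number if anything: a 1.8-fold lower number from compound 2 to compound 3 (0.26 log units; within the scatter).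

Compound 3 is therefore estimated at 4500 nM in this assay, with a range from 2000 nM to 10000 nM.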

Compound 3, concentration for 50% growth inhibition: 1050 nM
Estimate against measurement, compound 3: 4.3-fold (0.63 log units) above; measured number below the stated range.
By their numbers in this assay, from the lowest: compound 3; then compounds 1 and 2 (each within the scatter of the next).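

In (this assay) the nitrogen of the shared core, where the earlier pair gave no readable effect of acylation, now shows a step beyond the scatter when (3-chlorophenyl)carbonyl replaces hydrogen (a 7.7-fold lower number from compound 2 to compound 3 (0.89 log units; beyond the scatter)). The placing of the chlorine on the phenyl also counts at this nitrogen, since exchanging 4-chlorophenyl for 3-chlorophenyl on the carbonyl carbon gives a step of its own beyond the scatter (a 4.0-fold lower number from compound 1 to compound 3 (0.61 log units; beyond the scatter)), so acylation alone does not account for the lower number, and compound 1 goes against any such reading. No measurement offered here accounts for the difference between these two acyl groups.

The compounds shown leave open whether the chlorine of compound 3 is needed at all, or whether fluorine, a methoxy group or a plain hydrogen on the phenyl would serve equally well. They also leave open whether the phenyl ring itself is required on the carbonyl, as against a simple acetyl group or a longer alkyl chain, or a carbonyl bearing an amine.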